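This account rests on a few compounds, and the source may have more. Where it says the series, first, only, none or still open, it means among the compounds named here.

In a functional assay on SK-OV-3 cells (Homo sapiens) for inhibition, read by CCK-8 assay, with a stated time of 70 h (a higher number here means a weaker inhibitor, a lower number a stronger inhibitor), compound 1 `c1ccc(COc2ccc(OCCOCCNc3ccncc3)cc2)cc1` gives 20600 nM and compound 2 `c1ccc2cc(OCCOCCNC3CCCC3)ccc2c1` gives 40600 nM, so these two values lie within the usual scatter of each other. Compound 3 `c1ccc(COc2ccc(OCCOCCNC3CCOC3)cc2)cc1` keeps the core of compound 1 and differs in one place: oxolan-3-yl in place of pyridin-4-yl on an amine nitrogen, with oxolan-3-yl in place of pyridin-4-yl on an amine nitrogen. Among the measured compounds shown here, no measured pair shows this change, so the estimate rests on these two values alone. A modest move toward a higher number in this assay is expected, a 1.6-fold higher number from compound 1 to compound 3 (0.19 log units; within the scatter). Compound 3 is estimated at 32000 nM, within an expected range of 13000 nM to 80000 nM.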

Compound 3, half-maximal inhibitory concentration: 48000 nM
Beside the measured number, compound 3's estimate is 1.5-fold (0.18 log units) below it; measured number inside the range.
By their numbers in this assay, from the lowest: compounds 1, 2 and 3 (each within the scatter of the next, the first and the last beyond it).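

With the core of compound 1 held fixed, oxolan-3-yl in place of pyridin-4-yl on an amine nitrogen gives in this assay the first single-place step available here (a 2.3-fold higher number from compound 1 to compound 3 (0.37 log units; beyond the scatter)). This shows that the number at this position depends on the group carried there, though the step is modest. Nothing measured here explains the step.

The compounds shown leave open how a phenyl or a piperidin-4-yl group on the same amine nitrogen would read. They also leave open whether this step would hold with a longer chain.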